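Sulfonyl aryl swap carried onto the chloro core

The compounds below may be only part of what the source reports. "The series", "measured", "known", "first", "only" and "open" are said of these compounds alone.

Measured values in an assay on isolated protein for displacement of a labelled ligand from metabotropic glutamate receptor 5 (Homo sapiens), with a stated time of 60 min, tested at 1 uM; on this read-out lower numbers stand for less inhibition and higher numbers for more inhibition at the one concentration tested (going by the name of the read-out):
compound 1, `Cc1ccc2ncc(S(=O)(=O)c3ccc(C)c(Cl)c3)c(N3CCC(C)CC3)c2c1`, gives 91%.
compound 2, `Cc1ccc2ncc(S(=O)(=O)c3cccc(F)c3)c(N3CCC(C)CC3)c2c1`, gives 94%.
compound 3, `Cc1ccc(S(=O)(=O)c2cnc3ccc(Cl)cc3c2N2CCC(C)CC2)cc1Cl`, gives 81%.

Compound 4, `CC1CCN(c2c(S(=O)(=O)c3cccc(F)c3)cnc3ccc(Cl)cc23)CC1`, has not yet been measured in this assay.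

Two single-point changes connect the measured compounds. From compound 1 to compound 2 the change is 3-fluorophenyl in place of 3-chloro-4-methylphenyl on a sulfonyl sulfur, and it gives a number 3 percentage points higher from compound 1 to compound 2 (within the scatter). From compound 1 to compound 3 the change is chloro in place of methyl on an aromatic carbon, and it gives a number 10 percentage points lower from compound 1 to compound 3 (within the scatter). Compound 3 stands with the lowest of the three numbers; its nearest neighbour is compound 1, within the scatter, while compound 2 lies beyond the scatter from it.

Compound 4 differs from compound 3 by 3-fluorophenyl in place of 3-chloro-4-methylphenyl on a sulfonyl sulfur. The place line reads the same, word for word, as in the change from compound 1 to compound 2, so this is the same change made on the core of compound 3 rather than the core of compound 1; the two cores differ as described under (chloro in place of methyl on an aromatic carbon). The change occurs twice among these compounds and has one measured instance.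

The step from compound 3 to compound 4 in this assay is expected to be a number 3 percentage points higher from compound 3 to compound 4 (within the scatter), about as small as the earlier one, because a number 3 percentage points higher from compound 1 to compound 2 (within the scatter) stayed within the scatter. Whether the chloro core shifts the outcome of this change cannot be told from one instance. Compound 4 is therefore estimated at 84%, with a range from 72% to 94%.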

Compound 4, a percentage reported as inhibition, at one concentration (the size of the read-out at that concentration, not a potency): 58%
Compound 4: the middle estimate sits 26 percentage points above what was measured, and the stated range ends above it.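

In this assay the swap to 3-fluorophenyl on a sulfonyl sulfur gives a number 23 percentage points lower from compound 3 to compound 4 (beyond the scatter), and chloro in place of methyl on an aromatic carbon, with 3-fluorophenyl on the sulfonyl sulfur, gives a number 36 percentage points lower from compound 2 to compound 4 (beyond the scatter). The swap does not carry unchanged from the core of compound 1 to the core of compound 3, so its outcome in this series depends on the core that receives it: the same change on two cores in this assay, a number 3 percentage points higher (within the scatter) from compound 1 to compound 2 and a number 23 percentage points lower (beyond the scatter) from compound 3 to compound 4, 26 percentage points apart, beyond the scatter of two such steps. Both comparisons rest on the same four compounds and describe one interaction seen from two sides, so they do not show why it arises or whether it extends to other sulfonyl aryl groups: the same change on two cores in this assay, a number 10 percentage points lower (within the scatter) from compound 1 to compound 3 and a number 36 percentage points lower (beyond the scatter) from compound 2 to compound 4, 26 percentage points apart, beyond the scatter of two such steps.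

Going by these compounds, it remains open whether this dependence belongs to chloro specifically or would also appear with another group in its place, such as a methoxy group or a nitrile, and whether a sulfonyl-bound unsubstituted phenyl or a 3-chlorophenyl would follow compound 2 and compound 4. On these data alone, with a read-out at one concentration, it is also open how these percentages translate into potency across the four compounds.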